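A few compounds are considered here, and "the series" means these few. Any claim that something is new, unique, unknown or untested is made for them only; others in the source may bear on it.

Compound 2 `COC1CC(C(=O)N2CCc3nc(C#Cc4ccccc4)sc3C2)C1` stands at the edge of what the assay can report: in an assay on HEK293 cells for negative allosteric modulation of metabotropic glutamate receptor 5 (Homo sapiens), read by FLIPR, with a stated time of 1 h (on this read-out lower numbers stand for stronger inhibition and higher numbers for weaker inhibition), compound 2 gives > 10000 nM, which is a limit rather than a number. Its closest relative, compound 1 `CC1CC1C(=O)N1CCc2nc(C#Cc3ccccc3)sc2C1`, also sits at that edge, and in this assay compound 1 gives > 10000 nM, again only a limit. The step that the two limits leave unreadable from compound 1 to compound 2 therefore cannot be read. Compound 3 `O=C(C1CCCC1)N1CCc2nc(C#Cc3ccccc3)sc2C1` carries cyclopentyl in place of 3-methoxycyclobutyl on a carbonyl carbon. Among the compounds with values here, the only evidence is the limit of > 10000 nM in this assay, at which 2 of the 2 values shown sit, so no measured step bears on this change. Compound 3 is expected to remain near that limit, with an estimated step of a number no higher from compound 2 to compound 3 (the limit leaves the size open) and an estimate of 10000 nM, ranging from 3000 nM to 30000 nM.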

Compound 3, half-maximal inhibitory concentration: > 10000 nM
Compound 3 was reported as a limit (the forecaster's own chance of this, stated with the estimate: 80%); the middle value lies on the limit itself.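

No step can be read among compound 1, compound 2 and compound 3, since all three stop at one limit: the limit of > 10000 nM in this assay, at which 3 of the 3 values shown sit. From the compounds shown here alone, whether 2-methylcyclopropyl, 3-methoxycyclobutyl and cyclopentyl differ at all in this assay stays open.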